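A few compounds are considered here, and "the series" means these few. Any claim that something is new, unique, unknown or untested is made for them only; others in the source may bear on it.

Compound 2 `Cc1cc(C)nc(NS(=O)(=O)c2ccc(NCc3coc4ccccc4c3=O)cc2)n1` and compound 1 `Cc1cc(NS(=O)(=O)c2ccc(NCc3coc4ccccc4c3=O)cc2)no1` share a core and differ only by 5-methyl-1,2-oxazol-3-yl in place of 4,6-dimethylpyrimidin-2-yl on a sulfonamide nitrogen. In a functional assay on A549 cells (Homo sapiens) for cytotoxicity, read by sulforhodamine B assay, with a stated time of 72 h (on this read-out lower numbers stand for stronger inhibition and higher numbers for weaker inhibition), compound 2 gives 55800 nM, and compound 1 gives 59700 nM; the step of a 1.1-fold higher number from compound 2 to compound 1 (0.03 log units; within the scatter) is small. Compound 3 `Cc1cc(C)nc(NS(=O)(=O)c2ccc(NC3=NC(=O)/C(=C\c4coc5ccccc5c4=O)S3)cc2)n1` carries a different core; how it differs from compound 2 is not broken down here. For compound 3 the read-out is a limit, > 100000 nM, matching (the limit of > 100000 nM in this assay, at which 1 of the 3 values shown sits). Compound 4 `Cc1cc(NS(=O)(=O)c2ccc(NC3=NC(=O)/C(=C\c4coc5ccccc5c4=O)S3)cc2)no1` is not yet measured; it differs from compound 3 by 5-methyl-1,2-oxazol-3-yl in place of 4,6-dimethylpyrimidin-2-yl on a sulfonamide nitrogen, the same change as from compound 2 to compound 1. The step that the limit leaves unreadable from compound 3 to compound 4 is expected to be small, resting on the earlier step of a 1.1-fold higher number from compound 2 to compound 1 (0.03 log units; within the scatter). Compound 4 is therefore expected at about 130000 nM, within 60000 nM to 300000 nM, and most likely reported as a limit.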

Compound 4, half-maximal inhibitory concentration: > 100000 nM
Compound 4 ended at the assay's limit; the forecaster's own chance of this, stated with the estimate: 75%; the middle value lies beyond the limit too.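

Compound 3 and compound 4 both stand at a limit in this assay, and the step between them cannot be read. Still open, from the compounds shown here alone, is whether 5-methyl-1,2-oxazol-3-yl in place of 4,6-dimethylpyrimidin-2-yl matters on the core of compound 3.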